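Oxazole lactone series: phenyl to prop-1-en-1-yl on the oxazole

A few compounds are considered here, and "the series" means these few. Any claim that something is new, unique, unknown or untested is made for them only; others in the source may bear on it.

Measured compounds, cytotoxicity read-out:
- compound 1 `CC(=O)O[C@H]1C=CC(=O)O[C@@H]1c1nc(-c2ccccc2)oc1-c1ccccc1`: 12000 nM
- compound 2 `CC(=O)O[C@H]1C=CC(=O)O[C@H]1[C@H]1O[C@@H]1c1ccccc1`: 20300 nM
- compound 3 `CC(=O)O[C@H]1C=CC(=O)O[C@H]1[C@H]1OC(C)(C)O[C@@H]1c1ccccc1`: a limit of the assay, > 40000 nM

The read-out throughout is a functional assay on SK-BR-3 cells (Homo sapiens) for cytotoxicity, read by MTT assay, with a stated time of 48 h; a higher number here means a weaker inhibitor, a lower number a stronger inhibitor. Compound 1 holds the lowest of the two numbers that were actually obtained; the nearest is compound 2, whose number is higher, but the gap between the two lies within the scatter of repeated measurements, so no order between them can be claimed. Compound 3 gives only a limit, (the limit of > 40000 nM in this assay, at which 1 of the 3 values shown sits), and contributes no number.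

The next compound in the series is compound 4 `C/C=C\c1nc([C@H]2OC(=O)C=C[C@@H]2OC(C)=O)c(-c2ccccc2)o1`. Against compound 1 the single change is prop-1-en-1-yl in place of phenyl on an aromatic carbon; the rest of the core, the acetoxy lactone and the remaining phenyl, is kept. For the measured compounds named here, no step between measured compounds matches this change, so there is no measured precedent to lean on. Given that all numbers in the series sit in a narrow, weak region, the expectation is a step from compound 1 to compound 4 of no more than the scatter, a 1.3-fold higher number from compound 1 to compound 4 (0.10 log units; within the scatter), with a slight lean towards a higher number. Compound 4 is therefore estimated at 15000 nM, with a plausible range from 5000 nM to 40000 nM.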

Compound 4, half-maximal inhibitory concentration: > 40000 nM
Compound 4: no number, only a limit (the forecaster's own chance of this, stated with the estimate: 20%); at least 2.6-fold (0.42 log units) between middle value and limit.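

In this assay compound 4 gives > 40000 nM, which is a limit of the assay and not a number. For the compounds shown here, replacing phenyl with prop-1-en-1-yl on the aromatic carbon next to the ring nitrogen and next to the ring oxygen gives the first step that changes one place only, an at least 3.3-fold higher number from compound 1 to compound 4 (0.52 log units; beyond the scatter), so this position is not indifferent to its substituent and the measurable number of compound 1 does not survive this exchange. The step has a lower bound and no upper end, and compound 4 joins the compounds that give no number: the limit of > 40000 nM in this assay, at which 2 of the 4 values shown sit.

Going by these compounds alone, the single step cannot separate the departure of the six-membered aromatic ring from the arrival of the double bond outside aromatic rings, and a saturated propyl chain, a cyclohexyl ring or a phenyl ring carrying a methoxy group or an amine at the same position would be needed to tell these apart. Also open, going by these compounds, is whether any group at this position gives a number clearly lower than that of compound 1, and whether the phenyl group on the neighbouring ring atom responds to change in the same way.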